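Swapping a Pyridine for a Fluorophenyl in a Hydrazone Series

The compounds below may be only part of what the source reports. "The series", "measured", "known", "first", "only" and "open" are said of these compounds alone.

Compound 1 `COc1ccccc1-c1nnc(-c2ccc(C(=O)N/N=C/c3ccncc3)cc2)o1` and compound 2 `COc1ccccc1-c1nnc(-c2ccc(C(=O)N/N=C/c3ccccn3)cc2)o1` share a core and differ only in the ring attached to a carbon with a double bond to nitrogen. For the measured compounds named here, in an ADME assay on THP-1 cells (Homo sapiens) for cytotoxicity (a lower number here means a stronger inhibitor, a higher number a weaker inhibitor), compound 1 gives 173000 nM, the highest of the two numbers measured so far; in this assay compound 2 gives 67000 nM. Going by the values given here, the one known step, a 2.6-fold lower number from compound 1 to compound 2 (0.41 log units; beyond the scatter), shows that moving the nitrogen within that ring already shifts the number beyond the scatter.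

Compound 3 `COc1ccccc1-c1nnc(-c2ccc(C(=O)N/N=C/c3cccc(F)c3)cc2)o1` has not yet been measured. It differs from compound 1 as follows: 3-fluorophenyl in place of pyridin-4-yl on a carbon with a double bond to nitrogen. Among the compounds with values here, no measured step shows this exact change; the step from compound 1 to compound 2 bears on it only in that it alters the same ring in the same place, and it was modest in size. A change of similar or smaller size is therefore expected, most likely toward a lower number, as a 1.4-fold lower number from compound 1 to compound 3 (0.16 log units; within the scatter), but a result within the scatter is also plausible. For compound 3 in this assay the estimate is 120000 nM, with a range from 40000 nM to 300000 nM.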

Compound 3, half-maximal inhibitory concentration: 353000 nM
Compound 3: middle estimate off by 2.9-fold (0.47 log units), on the low side; the measured number lies above the stated range.
By their numbers in this assay, from the lowest: compound 2; then compound 1; then compound 3.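

In this assay, placing 3-fluorophenyl on the carbon with a double bond to nitrogen gives a 2.0-fold higher number from compound 1 to compound 3 (0.31 log units; beyond the scatter) and a 5.3-fold higher number from compound 2 to compound 3 (0.72 log units; beyond the scatter), so the number at this position can move upward as well as downward. Among these three compounds, the pyridin-2-yl ring of compound 2 gives the lowest number, the pyridin-4-yl ring of compound 1 lies in the middle, and the 3-fluorophenyl ring of compound 3 gives the highest, making compound 3 the weakest inhibitor of the three in this cell test. Nothing among the data gives a reason for this order.

This single change removes the ring nitrogen and adds a fluorine at once, so the compounds shown leave open how much of the rise belongs to each, a question that a plain phenyl ring would help to separate. They also leave open how the number would respond to a pyridin-3-yl ring, or to a ring carrying an amine or a carboxylic acid, at the same place.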